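Ester, acid and amide on the benzoate arm

The source may hold more compounds than are shown below. What is called first, only, known or untested is meant among the compounds shown, and "the series" means these compounds.

Compound 1 `COC(=O)c1ccc(COC(COCc2ccc(OC)cc2)Cn2ccnc2)cc1`: 1260 nM
Compound 2 `COc1ccc(COCC(Cn2ccnc2)OCc2ccc(C(=O)O)cc2)cc1`: 6700 nM

Going by the values given here, in a functional assay for inhibition of Thromboxane-A synthase (Homo sapiens) (on this read-out lower numbers stand for stronger inhibition and higher numbers for weaker inhibition), compound 2 stands highest of the two numbers; the only measured step, a 5.3-fold higher number from compound 1 to compound 2 (0.73 log units; beyond the scatter), is the one that leads to it. Compound 3 `CCNC(=O)c1ccc(COC(COCc2ccc(OC)cc2)Cn2ccnc2)cc1` carries ethylamino in place of hydroxy on a carbonyl carbon; cut one bond further out, carboxy to ethylcarbamoyl. That single step bears on the new change in so far as the hydroxy that entered with compound 2 now leaves again, so a move back toward the number of compound 1 is expected, not a gain beyond it. Compound 3 is estimated at 2000 nM, with a range of 700 nM to 6000 nM. This expected step is a 3.4-fold lower number from compound 2 to compound 3 (0.53 log units; beyond the scatter).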

Compound 3, half-maximal inhibitory concentration: 12400 nM
For compound 3 the middle estimate is 6.2-fold (0.79 log units) below the measured one, outside the stated range (above it).
By their numbers in this assay, from the lowest: compound 1; then compounds 2 and 3 (each within the scatter of the next).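

In this assay, ethylamino in place of hydroxy on the carbonyl carbon does not separate the ethyl amide from the carboxylic acid (a 1.9-fold higher number from compound 2 to compound 3 (0.27 log units; within the scatter)). Against the methyl ester, the same amide gives a step beyond the scatter (a 9.8-fold higher number from compound 1 to compound 3 (0.99 log units; beyond the scatter)), so of the three groups at this place, only the methoxy of compound 1 stands apart. No evidence at hand bears on the reason.

Going by these compounds, it remains open whether a longer ester, such as the ethyl ester, keeps the number of compound 1. Also open, on these data alone, is whether an unsubstituted amide or a dimethylamino group on the carbonyl carbon stays with compound 3.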